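A few compounds are considered here, and "the series" means these few. Any claim that something is new, unique, unknown or untested is made for them only; others in the source may bear on it.

Compound 1 `Cc1ccc(C(=O)Nc2sc3c(c2C(N)=O)CCOC3)s1`: 778 nM
Compound 2 `CC1Cc2c(sc(NC(=O)c3ccccc3O)c2C(N)=O)C(C)O1`: 4 nM
Compound 3 `CC1(C)Cc2c(sc(NC(=O)c3cccnc3O)c2C(N)=O)C(C)(C)O1`: 190 nM

The three compounds share one core and differ in the group attached to the amide carbonyl. In an assay on cells for positive allosteric modulation of Cystic fibrosis transmembrane conductance regulator variant F508del (Homo sapiens), with stated times of 10 min and 7 s, in the presence of a further agent that is not named here (a lower number here means that less compound is needed, a higher number that more compound is needed for the effect), compound 3 gives 190 nM, the second highest of the three numbers. Its nearest neighbour, compound 1, gives 778 nM, a higher number, and that gap lies beyond the usual scatter. Compound 2 gives 4 nM, a far lower number, again beyond the scatter. Compound 3 therefore sits in the middle, well apart from either neighbour.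

Compound 4 `CC1(C)Cc2c(sc(NC(=O)C3CNC(=O)C3)c2C(N)=O)C(C)(C)O1` has not yet been measured. It changes compound 3 in one place only: 5-oxopyrrolidin-3-yl in place of 2-hydroxypyridin-3-yl on a carbonyl carbon. A six-membered aromatic ring carrying a hydroxy group is thus traded for a five-membered non-aromatic ring. Among the measured compounds every group on this carbonyl carbon is an aromatic ring, so no measured step shows what a non-aromatic ring does here. Among the measured compounds shown here, with no comparable step to lean on, the expectation rests only on the wide spread already seen among the measured rings. The step of a 16-fold higher number from compound 3 to compound 4 (1.20 log units; beyond the scatter) is expected to go towards a higher number, beyond the scatter. For compound 4 the estimated value is 3000 nM, within a range from 600 nM to 15000 nM.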

Compound 4, half-maximal effective concentration: > 10000 nM
Compound 4: a limit, no number; the forecaster's own chance of this, stated with the estimate: 25%; middle value at least 3.3-fold (0.52 log units) away from the limit.
By their numbers in this assay, from the lowest: compound 2; then compound 3; then compound 1. At a limit, above all of these: compound 4.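

This piece now has its first non-aromatic ring on the carbonyl carbon, and in this assay the reading for compound 4 is a limit and not a number: the limit of > 10000 nM in this assay, at which 1 of the 4 values shown sits. The swap of 2-hydroxypyridin-3-yl for 5-oxopyrrolidin-3-yl gives an at least 52-fold higher number from compound 3 to compound 4 (1.72 log units; beyond the scatter), a large step, so this place on the shared core does not accept just any ring, and the effect seen with an aromatic ring here is lost with this non-aromatic one. Both groups count one hydrogen-bond donor, so keeping that count was not enough on its own to keep the effect.

Ring size, aromatic character, the hydroxy group and the number of hydrogen-bond acceptors all change together in this one step, so the compounds shown cannot say which of these differences matters. As far as these compounds go, it also stays open whether a cyclohexyl ring, a plain phenyl ring without the hydroxy group, or an open chain ending in a carboxylic acid on this carbonyl carbon would stay close to compound 3 or fall away as compound 4 does.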